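The source may report more compounds than this note shows. Statements on the series, on what has been measured and on what is new or still open speak of the compounds shown alone.

Of the compounds shown here, three built on one shared core have been measured in an assay for activation of Adrenergic receptor alpha-1 (Rattus norvegicus); on this read-out higher numbers stand for an effect only at larger amounts of compound and lower numbers for an effect already at smaller amounts. Compound 1 `c1ccc2c(c1)CC2CN1CCN(c2cccc3c2OCCO3)CC1` gives 0.7 mg/kg, compound 2 `c1ccc2c(c1)CC2CCCN1CCN(c2cccc3c2OCCO3)CC1` gives 0.45 mg/kg, and compound 3 `c1ccc2c(c1)CCC2CCN1CCN(c2cccc3c2OCCO3)CC1` gives 4.01 mg/kg. Compound 2 has the lowest of these three numbers, although its gap to compound 1 lies within the scatter. Compound 4 `c1ccc2c(c1)CC(CCCN1CCN(c3cccc4c3OCCO4)CC1)C2` differs from compound 2 by a group of 9 heavy atoms (9 carbon; one five-membered non-aromatic ring of carbon only, one six-membered aromatic ring of carbon only) in place of a group of 8 heavy atoms (8 carbon; one four-membered non-aromatic ring of carbon only, one six-membered aromatic ring of carbon only), on a saturated chain carbon, three bonds along the chain from an amine nitrogen in a ring. Among the compounds with values here, the one measured step that bears on this also put a five-membered ring in place of a four-membered one: an 8.9-fold higher number from compound 2 to compound 3 (0.95 log units; beyond the scatter). Because of an 8.9-fold higher number from compound 2 to compound 3 (0.95 log units; beyond the scatter), the step expected here is estimated as a 4.0-fold higher number from compound 2 to compound 4 (0.60 log units; beyond the scatter), a more modest step toward a higher number. Compound 4 is therefore estimated at 1.8 mg/kg, within a range from 0.6 mg/kg to 5.5 mg/kg.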

Compound 4, dose for half-maximal effect: 1.73 mg/kg
For compound 4 the middle estimate is 1.0-fold (0.02 log units) above the measured one; the measured number falls inside the stated range.
By their numbers in this assay, from the lowest: compounds 2 and 1 (each within the scatter of the next); then compound 4; then compound 3.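

Putting 2,3-dihydro-1H-inden-2-yl in place of the group with the four-membered ring, on a saturated chain carbon three bonds along the chain from an amine nitrogen in a ring, gives a 3.8-fold higher number from compound 2 to compound 4 (0.58 log units; beyond the scatter). Within the data shown here, the only earlier ring change, an 8.9-fold higher number from compound 2 to compound 3 (0.95 log units; beyond the scatter), sat two bonds along the chain, so a higher number with the five-membered ring now appears at both places. Nothing measured here explains this shift. Going by these compounds, whether a longer chain carrying 2,3-dihydro-1H-inden-2-yl, or an amine on that group, would change the number in this assay stays open.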